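Pyridinyl in place of the pyrazolyl on a shared core

A few compounds are considered here, and "the series" means these few. Any claim that something is new, unique, unknown or untested is made for them only; others in the source may bear on it.

Compound 1, `Cc1n[nH]cc1-c1cccc2c1CCC2c1ncc[nH]1`, gives 3 nM in a functional assay on CHO cells for agonist activity at Alpha-1A adrenergic receptor (Homo sapiens), read by FLIPR and calcium flux; on this read-out higher numbers stand for an effect only at larger amounts of compound and lower numbers for an effect already at smaller amounts.
Compound 2, `c1ccc2c(c1)CCC2c1ncc[nH]1`, gives 473 nM in this assay.
Compound 3, `CS(=O)(=O)Nc1cccc2c1CCC2c1ncc[nH]1`, gives 70 nM in this assay.

Compound 1 stands lowest of the three numbers; the nearest to it is compound 3, and the step there is a 23-fold higher number from compound 1 to compound 3 (1.37 log units; beyond the scatter), while the furthest is compound 2, with a 160-fold higher number from compound 1 to compound 2 (2.20 log units; beyond the scatter). Between those two, the step is a 6.8-fold lower number from compound 2 to compound 3 (0.83 log units; beyond the scatter).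

Compound 4, `c1cncc(-c2cccc3c2CCC3c2ncc[nH]2)c1`, has not yet been measured. The change from compound 1 is pyridin-3-yl in place of 3-methyl-1H-pyrazol-4-yl on an aromatic carbon. For the measured compounds named here, two measured steps bear on it, both starting from compound 1: a 160-fold higher number from compound 1 to compound 2 (2.20 log units; beyond the scatter) shows how much is lost when the group is removed altogether, and a 23-fold higher number from compound 1 to compound 3 (1.37 log units; beyond the scatter) shows that a different group at the same carbon also loses a large part of it. A new aromatic ring at that carbon is expected to keep more than hydrogen does, but the step is still expected to go toward higher numbers, beyond the scatter, so compound 4 is estimated at 30 nM (range 5 nM to 200 nM), which means an expected step of a 10-fold higher number from compound 1 to compound 4 (1.00 log units; beyond the scatter).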

Compound 4, half-maximal effective concentration: 2060 nM
Compound 4: the middle estimate sits 69-fold (1.84 log units) below what was measured, outside the stated range (above it).
By their numbers in this assay, from the lowest: compound 1; then compound 3; then compound 2; then compound 4.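

At this carbon, an aromatic ring alone does not preserve the low number of compound 1: in this assay the swap to pyridin-3-yl brings a 690-fold higher number from compound 1 to compound 4 (2.84 log units; beyond the scatter) and the result lies even beyond that of the bare core, with a 4.4-fold higher number from compound 2 to compound 4 (0.64 log units; beyond the scatter) when hydrogen gives way to the same ring. The non-aromatic methanesulfonamido group also keeps a much lower number, as a 29-fold higher number from compound 3 to compound 4 (1.47 log units; beyond the scatter) shows when it gives way to pyridin-3-yl, so at this position an aromatic ring can do worse than either hydrogen or methanesulfonamido. No measurement on hand accounts for the gap between the two aromatic rings.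

The compounds shown leave open how an unsubstituted 1H-pyrazol-4-yl, a phenyl ring or a pyridin-4-yl would stand at this carbon. They also leave open where a simple amine would fall there.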